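A few compounds are considered here, and "the series" means these few. Any claim that something is new, unique, unknown or untested is made for them only; others in the source may bear on it.

Compound 1 `CC[C@H](N)C(=O)N[C@@H]1C(=O)N2[C@@H](CC[C@@H]1CCO)CC[C@H]2C(=O)NC(c1ccccc1)c1ccccc1`: 1800 nM
Compound 2 `CC[C@H](NC)C(=O)N[C@@H]1C(=O)N2[C@@H](CC[C@@H]1CCNC(=O)NCc1ccccc1)CC[C@H]2C(=O)NC(c1ccccc1)c1ccccc1`: 1200 nM
Compound 3 `CCNCC[C@H]1CC[C@H]2CC[C@@H](C(=O)NC(c3ccccc3)c3ccccc3)N2C(=O)[C@H]1NC(=O)[C@H](CC)NC`: 1300 nM

All three compounds were tested in a functional assay on MDA-MB-231 cells (Homo sapiens) for cytotoxicity, read by MTT assay, with a stated time of 96 h; on this read-out lower numbers stand for stronger inhibition and higher numbers for weaker inhibition. There, compound 1 gives 1800 nM, a number within the scatter of those of compound 2 and compound 3, so the three cannot be ranked.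

The step followed here leads from compound 1 to compound 4 `CC[C@H](N)C(=O)N[C@@H]1C(=O)N2[C@@H](CC[C@@H]1CCNCc1ccccc1)CC[C@H]2C(=O)NC(c1ccccc1)c1ccccc1`, which keeps the shared core and alters the end of the chain: benzylamino in place of hydroxy on a saturated chain carbon, two bonds along the chain from a saturated ring carbon. Benzylamino stands in place of hydroxy on a saturated chain carbon, two bonds along the chain from a saturated ring carbon.

For the measured compounds named here, one measured step bears on this chain end. Ethyl in place of benzylcarbamoyl on an amine nitrogen gives a 1.1-fold higher number from compound 2 to compound 3 (0.03 log units; within the scatter), which lies within the scatter. Going by the values given here, compound 2 and compound 3 also differ from compound 1 elsewhere, and no measured compound carries benzylamino, so this evidence is indirect. No step beyond the scatter is therefore expected in this assay.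

The expected step is a 1.4-fold lower number from compound 1 to compound 4 (0.14 log units; within the scatter).

For compound 4 the estimated value is 1300 nM, with an expected range of 500 nM to 3200 nM.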

Compound 4, half-maximal inhibitory concentration: 400 nM
Beside the measured number, compound 4's estimate is 3.3-fold (0.51 log units) above it; the measured number lies below the stated range.
By their numbers in this assay, from the lowest: compound 4; then compounds 2, 3 and 1 (each within the scatter of the next).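

In this assay, benzylamino in place of hydroxy on a saturated chain carbon, two bonds along the chain from a saturated ring carbon, gives a 4.5-fold lower number from compound 1 to compound 4 (0.65 log units; beyond the scatter). For the compounds shown here, this is the first step at this chain end that lies beyond the scatter; the one earlier step bearing on this end, a 1.1-fold higher number from compound 2 to compound 3 (0.03 log units; within the scatter), stayed within it and involved a different exchange on an amine nitrogen, so the chain end can shift the number after all. Nothing measured here accounts for the size of this step.

Going by these compounds, whether the step belongs to the amine nitrogen or to the six-membered aromatic ring stays open, and a primary amine or a benzyl ether at the chain end would separate the two. Also open, on these data alone, is how a longer chain carrying benzylamino would read.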